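The source may hold more compounds than are shown below. What is called first, only, known or untested is meant among the compounds shown, and "the series" means these compounds.

Measured compounds in a functional assay on WiDr cells (Homo sapiens) for inhibition, read by sulforhodamine B assay, with a stated time of 48 h; on this read-out lower numbers stand for stronger inhibition of growth and higher numbers for weaker inhibition of growth:

compound 1 `COC(=O)[C@@]1(C)CCC=C2[C@@H]1CC[C@@H](C)[C@]2(C)Cc1c[nH]c2ccc(C)cc12` — 22000 nM
compound 2 `COC(=O)[C@@]1(C)CCC=C2[C@@H]1CC[C@@H](C)[C@]2(C)Cc1c[nH]c2c(C)cccc12` — 26000 nM
compound 3 `COC(=O)[C@@]1(C)CCC=C2[C@@H]1CC[C@@H](C)[C@]2(C)Cc1c(C)[nH]c2ccc(C)cc12` — 28000 nM

The three numbers in this assay lie within the scatter of one another, so compound 3 is not set apart from compound 1 or compound 2; its nearest neighbour is compound 2, its furthest compound 1, and neither gap is beyond the scatter.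

Compound 4 `COC(=O)[C@@]1(C)CCC=C2[C@@H]1CC[C@@H](C)[C@]2(C)Cc1c(C)[nH]c2ccc(F)cc12` is not yet measured. It differs from compound 3 in one place: fluoro in place of methyl on an aromatic carbon.

Going by the values given here, only one measured step touches the aromatic carbons of this part of the core: a 1.3-fold higher number from compound 1 to compound 3 (0.10 log units; within the scatter), and it is within the scatter. Compound 1 and compound 2, which carry the methyl on different aromatic carbons, also sit within the scatter of each other. Among the compounds with values here, no measured pair shows fluoro in place of methyl, so the change in compound 4 has no direct precedent here. On what is known, substituent changes on this ring have not moved the number beyond the scatter, and no step beyond the scatter is expected in this assay for compound 4 in either direction.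

Compound 4 is therefore expected to give about 28000 nM, with a range of 12000 nM to 65000 nM. For compound 4 this estimate means no change at the digits printed from compound 3 to compound 4 (within the scatter).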

Compound 4, concentration for 50% growth inhibition: 17000 nM
The estimate for compound 4 lay 1.6-fold (0.22 log units) above the measured number, and the stated range covers the measured number.
By their numbers in this assay, from the lowest: compounds 4, 1, 2 and 3 (each within the scatter of the next).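

In this assay, fluoro in place of methyl on this aromatic carbon, meta to a fused ring and para to a fused ring, gives a 1.6-fold lower number from compound 3 to compound 4 (0.22 log units; within the scatter). Earlier compounds had shown only an exchange of hydrogen for methyl on an aromatic carbon, so this is the first sign that a fluoro group can stand at this position without setting the compound apart from its methyl partner, although a step of this size cannot be read as a real gain in growth inhibition. No measurement is available that bears on the origin of this small step.

Still open is whether any group on this aromatic carbon can move the number beyond the scatter, since compounds carrying a methoxy group, an amine or a carboxylic acid there are not among those shown. The compounds shown also leave open how far the number depends on the methyl ester of the shared core, for which a carboxylic acid or an amide would be the direct comparison.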